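Chloro to Fluoro Swap: Notes Toward Compound 4

A few compounds are considered here, and "the series" means these few. Any claim that something is new, unique, unknown or untested is made for them only; others in the source may bear on it.

Measured compounds in an ADME assay on GES1 cells (Homo sapiens) for inhibition, read by MTT assay, with a stated time of 72 h; on this read-out higher numbers stand for weaker inhibition and lower numbers for stronger inhibition:
compound 1, `Cc1cc(Nc2cc(-c3ccccc3)[nH]n2)n2nc(SCc3ccc(F)cc3)nc2n1`, 35500 nM
compound 2, `Cc1cc(Nc2cc(-c3ccccc3)[nH]n2)n2nc(SCc3ccc(Cl)cc3)nc2n1`, 31800 nM
compound 3, `Cc1cc(Nc2cc(-c3ccc(Cl)cc3)[nH]n2)n2nc(SCc3ccc(Br)cc3)nc2n1`, 28200 nM

All three numbers sit close together. The difference between the core of compound 2 and the core of compound 3 is not broken down here; their two values lie within the scatter of each other. Between compound 2 and compound 1 the change is fluoro in place of chloro on an aromatic carbon; it made a 1.1-fold higher number from compound 2 to compound 1 (0.05 log units; within the scatter).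

Compound 4, `Cc1cc(Nc2cc(-c3ccc(F)cc3)[nH]n2)n2nc(SCc3ccc(Br)cc3)nc2n1`, has not been measured in this assay. It differs from compound 3 by fluoro in place of chloro on an aromatic carbon, the same change, at a place described in the same words. The expected step is a 1.1-fold higher number from compound 3 to compound 4 (0.03 log units; within the scatter), resting on the one earlier occurrence, which gave a 1.1-fold higher number from compound 2 to compound 1 (0.05 log units; within the scatter). On this basis compound 4 is estimated at 30000 nM, with a likely range from 15000 nM to 60000 nM.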

Compound 4, half-maximal inhibitory concentration: 34200 nM
Estimate against measurement, compound 4: 1.1-fold (0.06 log units) below, within the range that was stated.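

In this assay the change of 4-chlorophenyl to 4-fluorophenyl gives a 1.2-fold higher number from compound 3 to compound 4 (0.08 log units; within the scatter) and agrees with the earlier fluoro-for-chloro step on the other core: the same change on two cores in this assay, a 1.1-fold higher number (0.05 log units; within the scatter) from compound 2 to compound 1 and a 1.2-fold higher number (0.08 log units; within the scatter) from compound 3 to compound 4, 1.1-fold (0.04 log units) apart, within the scatter of two such steps

So the swap carried across these two cores without a visible difference. Going by these compounds alone, both steps lie within the scatter, however, so neither shows a real effect of the swap, and the agreement shows only that two small steps match, not that the change would behave alike on further cores.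

The aromatic rings shown carry only hydrogen, fluoro, chloro or bromo, so an amine, a carboxylic acid or a methoxy group at those places remains open. Also open, from the compounds shown here alone, is a longer chain in place of the methyl on the shared core.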